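This account rests on a few compounds, and the source may have more. Where it says the series, first, only, none or still open, it means among the compounds named here.

In an ADME assay on cells (Fibroblast, Homo sapiens) for antiproliferative activity, with a stated time of 48 h (on this read-out lower numbers stand for stronger inhibition and higher numbers for weaker inhibition), compound 1 `CCN(CC)c1ccc(-c2ccc(C(=O)OC)cc2)nn1` gives 100 nM and compound 2 `CCOC(=O)c1ccc(-c2ccc(N(CC)CC)nn2)cc1` gives 3000 nM. Compound 3 `CCOC(=O)c1ccc(-c2ccc(N(C)C)nn2)cc1` gives > 25000 nM, which is a limit of the assay and not a number. Within the data shown here, it is therefore the one compound of the three without a measured value, standing at the limit of > 25000 nM in this assay, at which 1 of the 3 values shown sits.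

Compound 4 `COC(=O)c1ccc(-c2ccc(N(C)C)nn2)cc1` has not yet been measured. It differs from compound 3 as follows: hydrogen in place of methyl on a saturated chain carbon bound to an oxygen next to a carbonyl group. This places hydrogen in place of methyl on a saturated chain carbon bound to an oxygen next to a carbonyl group, turning the ethoxycarbonyl into methoxycarbonyl.

The closest evidence is the same change in the opposite direction, which is a 30-fold higher number from compound 1 to compound 2 (1.48 log units; beyond the scatter). The other measured step, an at least 8.3-fold higher number from compound 2 to compound 3 (0.92 log units; beyond the scatter), bears on the amino group and shows that the dimethylamino compound 3 starts from a weak position. Compound 1 and compound 2 both carry diethylamino, so the size of the ester effect with dimethylamino remains uncertain. A large fall in the number is nonetheless expected, and the expected step is an at least 12-fold lower number from compound 3 to compound 4 (1.09 log units; beyond the scatter). The estimate for compound 4 is 2000 nM, with an expected range from 400 nM to 12000 nM.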

Compound 4, half-maximal inhibitory concentration: > 25000 nM
Compound 4 ended at the assay's limit; the forecaster's own chance of this, stated with the estimate: 10%; at least 12-fold (1.09 log units) between middle value and limit.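

In this assay compound 4 gives > 25000 nM, which is a limit of the assay and not a number, so the dimethylamino compounds now both rest at that limit: the limit of > 25000 nM in this assay, at which 2 of the 4 values shown sit. With limits on both sides, the step for ethoxycarbonyl to methoxycarbonyl cannot be read, and the clear drop in the number that this change gave with diethylamino is not shown to carry over to dimethylamino. What the result adds is a second reading of the amino change, this time with methoxycarbonyl, where dimethylamino in place of diethylamino on an aromatic carbon gives an at least 250-fold higher number from compound 1 to compound 4 (2.39 log units; beyond the scatter), and the two readings can be set side by side: the same change on two cores in this assay, an at least 8.3-fold higher number (0.92 log units; beyond the scatter) from compound 2 to compound 3 and an at least 250-fold higher number (2.39 log units; beyond the scatter) from compound 1 to compound 4; the limit leaves it open whether they differ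

The compounds shown leave open how far past the limit compound 3 and compound 4 lie, and so whether the ester change does anything at all with dimethylamino. They also leave open how a propyl ester, a carboxylic acid in place of the ester, or dipropylamino in place of diethylamino would read on this core.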